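The compounds below may be only part of what the source reports. "The series", "measured", "known", "first", "only" and "open" are said of these compounds alone.

Measured in a functional assay on cells (Leukemia cell, Homo sapiens) for inhibition, with a stated time of 48 h; on this read-out lower numbers stand for stronger inhibition of growth and higher numbers for weaker inhibition of growth:
- Compound 1 `COc1cc2c(/C=C3/C(=O)Nc4ccc(Br)cc43)c(Cl)n(C)c2cc1C`: 2510 nM
- Compound 2 `COc1cc2c(/C=C3/C(=O)N(C)c4ccc(O)cc43)c(Cl)n(C)c2cc1C`: 50 nM
- Compound 3 `COc1cc2c(/C=C3/C(=O)N(C)c4ccccc43)c[nH]c2cc1C`: 2000 nM

Compound 3, at 2000 nM, lies within the scatter of compound 1 at 2510 nM. Compound 2 gives 50 nM. The gap between compound 3 and compound 2 lies beyond the scatter, with compound 2 at the lower number. Compound 4 `COc1cc2c(/C=C3/C(=O)N(C)c4ccc(O)cc43)c[nH]c2cc1C` differs from compound 3 by hydroxy in place of hydrogen on an aromatic carbon.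

For the measured compounds named here, no measured pair differs in one place only, so the size of this step cannot be read directly. Going by the values given here, the only hint comes from compound 2, which carries the same hydroxy and gives 50 nM in this assay. However, compound 2 also differs from compound 3 elsewhere, so the hydroxy may account for only part of that gap. A step beyond the scatter toward stronger inhibition of growth is therefore expected, though probably not one that reaches the full gap. The expected change is a 6.7-fold lower number from compound 3 to compound 4 (0.82 log units; beyond the scatter). For compound 4 the estimated value is 300 nM, with an expected range of 70 nM to 1300 nM.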

Compound 4, concentration for 50% growth inhibition: 3470 nM
Compound 4: the middle estimate sits 12-fold (1.06 log units) below what was measured; measured number above the stated range.
By their numbers in this assay, from the lowest: compound 2; then compounds 3, 1 and 4 (each within the scatter of the next).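

In this assay, hydroxy in place of hydrogen on an aromatic carbon gives a 1.7-fold higher number from compound 3 to compound 4 (0.24 log units; within the scatter), so on the core of compound 3 this change at this position does not separate the two compounds. The hydroxy that compound 4 shares with compound 2 therefore brings no step beyond the scatter on this core, and the low number of compound 2, 50 nM, cannot be read as the work of the hydroxy alone. No supporting measurement bears on why the step is this small.

For the compounds shown here, whether the hydroxy matters on the core of compound 2, which has other substituents, stays open, as no pair of compounds differing in one place reads it there. Also open, going by these compounds, is whether an amine or a methoxy on the same aromatic carbon would give a step beyond the scatter.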